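The compounds below may be only part of what the source reports. "The series", "measured", "known", "first", "only" and "open" are said of these compounds alone.

Measured compounds:
Compound 1 `CCOc1cc(NC(=O)C2(NC(=O)c3ccc4c(C5CCCC5)c(-c5ncc(Cl)cn5)n(C)c4c3)CCC2)ccc1/C=C/C(=O)OCOP(=O)(O)O`: 0.167 h
Compound 2 `CCOc1cc(NC(=O)C2(NC(=O)c3ccc4c(C5CCCC5)c(-c5ncc(Cl)cn5)n(C)c4c3)CCC2)ccc1/C=C/C(=O)OCC(Cl)(Cl)Cl`: a limit of the assay, > 5 h
Compound 3 `CCOc1cc(NC(=O)C2(NC(=O)c3ccc4c(C5CCCC5)c(-c5ncc(Cl)cn5)n(C)c4c3)CCC2)ccc1/C=C/C(=O)OCCOc1ccccc1`: a limit of the assay, > 5 h

In an ADME assay (liver) for pharmacokinetics, with Liver microsome (Homo sapiens) as the target, using microsomes (a higher number here means that the compound lasts longer, a lower number that the compound disappears faster), compound 3 stands at a limit, not a number, and shares that with the limit of > 5 h in this assay, at which 2 of the 3 values shown sit. Compound 4 `CCOc1cc(NC(=O)C2(NC(=O)c3ccc4c(C5CCCC5)c(-c5ncc(Cl)cn5)n(C)c4c3)CCC2)ccc1/C=C/C(=O)OCC(=O)OCc1ccc(Cl)cc1` differs from compound 3 by ((4-chlorobenzyl)oxy)carbonyl in place of phenoxymethyl on a saturated chain carbon bound to an oxygen next to a carbonyl group. Among the measured compounds shown here, two measured steps bear on this position: an at least 29-fold higher number from compound 1 to compound 2 (1.47 log units; beyond the scatter) and an at least 29-fold higher number from compound 1 to compound 3 (1.47 log units; beyond the scatter), while a step that the two limits leave unreadable from compound 2 to compound 3. Both steps that kept a carbon group there gave long half-lives, so compound 4, which also carries a carbon group, is expected to stay long, with an at least 1.2-fold lower number from compound 3 to compound 4 (0.09 log units; that floor lies within the scatter). Compound 4 is therefore estimated at 4 h, within 1 h to 6 h.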

Compound 4, half-life: 5.62 h
Beside the measured number, compound 4's estimate is 1.4-fold (0.15 log units) below it, and the stated range covers the measured number.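

Compound 4 gives 5.62 h in this assay, a true number rather than a limit, so the ((4-chlorobenzyl)oxy)carbonyl group adds a third carbon-based group at this position that lasts long, with a 34-fold higher number from compound 1 to compound 4 (1.53 log units; beyond the scatter). Among the four compounds, only compound 1, with its phosphorus-bearing group, disappears fast. The steps from compound 2 and from compound 3 to compound 4 cannot be read because they rest on a limit, not a number: the limit of > 5 h in this assay, at which 2 of the 4 values shown sit.

As far as these compounds go, how compound 2, compound 3 and compound 4 rank among themselves stays open. So does the half-life with an amine or a carboxylic acid at this position.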